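A few compounds are considered here, and "the series" means these few. Any claim that something is new, unique, unknown or untested is made for them only; others in the source may bear on it.

Measured in a functional assay on a cell-free system (Platelet, plasma, Oryctolagus cuniculus) for inhibition, with a stated time of 5 min, at 37 degrees C; a higher number here means a weaker inhibitor, a lower number a stronger inhibitor:

- Compound 1 `Cc1nc(C)c(C(=O)Oc2ccccc2/C=C/C(=O)O)nc1C`: 9600 nM
- Compound 2 `COc1ccc(/C=C/C(=O)O)c(OC(=O)c2nc(C)c(C)nc2C)c1`: 134000 nM
- Compound 3 `COc1cc(/C=C/C(=O)O)ccc1OC(=O)c1nc(C)c(C)nc1C`: 44600 nM

Of these three, compound 1 has the lowest number and is therefore the strongest inhibitor in this assay. Compound 4 `Cc1nc(C)c(C(=O)Oc2ccc(Cl)cc2/C=C/C(=O)O)nc1C` has not yet been measured. It departs from compound 1 by a single change: chloro in place of hydrogen on an aromatic carbon.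

Among the measured compounds shown here, only one measured step bears directly on this change. Adding methoxy in place of hydrogen on an aromatic carbon gave a 14-fold higher number from compound 1 to compound 2 (1.14 log units; beyond the scatter), a large loss of inhibition. That step involves a different group, so it indicates direction better than size. Compound 3 offers weaker support: at 44600 nM, compound 3 also gives a higher number than compound 1, but it is not a single-change neighbour of that compound. For the measured compounds named here, no measured compound carries chloro, so the size of the step remains uncertain.

A moderate rise in the number is therefore expected, smaller than the methoxy step. The expected change is a 1.7-fold higher number from compound 1 to compound 4 (0.22 log units; within the scatter). For compound 4 the estimated value is 16000 nM, with an expected range from 4500 nM to 60000 nM.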

Compound 4, half-maximal inhibitory concentration: 57200 nM
Estimate against measurement, compound 4: 3.6-fold (0.55 log units) below, and the stated range covers the measured number.
By their numbers in this assay, from the lowest: compound 1; then compounds 3 and 4 (each within the scatter of the next); then compound 2.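

In this assay, chloro meta to a 2-carboxyethenyl group and para to a large group costs inhibition, with a 6.0-fold higher number from compound 1 to compound 4 (0.78 log units; beyond the scatter), so a substituent of 1 heavy atom at this ring carbon is enough to move the number beyond the scatter. Among the compounds shown here, until now the only single-change evidence on this aromatic ring came from methoxy, with a 14-fold higher number from compound 1 to compound 2 (1.14 log units; beyond the scatter); chloro now gives a second case, and in both of these single changes the added group leaves a weaker inhibitor than compound 1, with neither going against that direction. The data shown offer no measurement that accounts for the loss seen with chloro.

Going by these compounds, it remains open whether the loss belongs to chloro itself or to any group placed on this ring carbon, since fluoro, methyl and an amine do not appear here at this place. Also unsettled is whether chloro would have the same effect in a compound that already carries methoxy on the ring, as no compound shown holds both groups.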